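Carboxypyridinyl variant of the oxazole ketone series

A few compounds are considered here, and "the series" means these few. Any claim that something is new, unique, unknown or untested is made for them only; others in the source may bear on it.

Compound 2 `NC(=O)c1cccc(-c2cnc(C(=O)CCc3ccc(-c4ccccc4)cc3)o2)n1` gives 1.2 nM in an assay for inhibition of Fatty-acid amide hydrolase 1 (Rattus norvegicus) (on this read-out lower numbers stand for stronger inhibition and higher numbers for weaker inhibition), the lowest of the three numbers in hand. Compound 1 `COC(=O)c1cc(-c2cnc(C(=O)CCc3ccc(-c4ccccc4)cc3)o2)ccn1` gives 1.5 nM, and the step of a 1.3-fold lower number from compound 1 to compound 2 (0.10 log units; within the scatter) sits within the scatter, so the two cannot be ordered. Compound 3 `O=C(CCc1ccc(-c2ccccc2)cc1)c1ncc(-c2cccc(-c3nnn[nH]3)n2)o1` gives 25 nM, and the step of a 21-fold higher number from compound 2 to compound 3 (1.32 log units; beyond the scatter) is large, well beyond the scatter.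

The unmeasured compound 4 `O=C(O)c1ccc(-c2cnc(C(=O)CCc3ccc(-c4ccccc4)cc3)o2)cn1` differs from compound 2 by 6-carboxypyridin-3-yl in place of 6-carbamoylpyridin-2-yl on an aromatic carbon. For the measured compounds named here, two measured steps bear on this. The step of a 1.3-fold lower number from compound 1 to compound 2 (0.10 log units; within the scatter) shows that moving the pyridine attachment and swapping the substituent did little. The step of a 21-fold higher number from compound 2 to compound 3 (1.32 log units; beyond the scatter) shows that replacing carbamoyl with a different group cost a great deal. Going by the values given here, the carboxy group of compound 4 is a third substituent in that position of the pyridine, with the same donor and acceptor count as carbamoyl, but no measured compound carries it, and no data separate the effect of moving the attachment from the effect of the new group. Compound 4 is therefore expected to weaken, with a step of a 10-fold higher number from compound 2 to compound 4 (1.00 log units; beyond the scatter), smaller than the loss seen for compound 3 but beyond the scatter. Compound 4 is estimated at 12 nM, with a range from 3 nM to 50 nM.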

Compound 4, inhibition constant: 44 nM
Estimate against measurement, compound 4: 3.7-fold (0.56 log units) below, within the range that was stated.
By their numbers in this assay, from the lowest: compounds 2 and 1 (each within the scatter of the next); then compounds 3 and 4 (each within the scatter of the next).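

In this assay, for the compounds shown here, the 6-carboxypyridin-3-yl group is the first change at this aromatic carbon of the oxazole-bearing core to pair a new attachment with a large loss, giving a 37-fold higher number from compound 2 to compound 4 (1.56 log units; beyond the scatter) and a 29-fold higher number from compound 1 to compound 4 (1.47 log units; beyond the scatter). The earlier pair, compound 1 and compound 2, had left the impression that this position tolerates a change of attachment and substituent, but compound 4 shows that this does not extend to every such change, and it falls with compound 3 rather than with compound 1 and compound 2. The groups leaving and entering match in heavy atoms, hydrogen-bond donors, hydrogen-bond acceptors and net charge as counted, so these counts do not separate compound 2 from compound 4, and no measurement shown gives a reason for the loss.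

The attachment point on the pyridine and the substituent change together in this step, so their shares of the loss cannot be told apart. A carboxylic acid on the same attachment as in compound 2, or a primary amine at that place on the pyridine, would bear on this question.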